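A few compounds are considered here, and "the series" means these few. Any claim that something is new, unique, unknown or untested is made for them only; others in the source may bear on it.

Compound 1, `N[C@]1(C(=O)O)[C@H]2[C@@H](C[C@H]1OCc1ccccc1Cl)[C@]2(F)C(=O)O`: 4.99 nM
Compound 2, `N#Cc1cccc(CO[C@@H]2C[C@@H]3[C@H]([C@]2(N)C(=O)O)[C@@]3(F)C(=O)O)c1`: 2.94 nM
Compound 3, `N[C@]1(C(=O)O)[C@H]2[C@@H](C[C@H]1OCc1cc(F)cc(F)c1)[C@]2(F)C(=O)O`: 12.4 nM

These three compounds share one core and differ only in the aromatic group carried on a saturated chain carbon bound to an oxygen on a saturated carbon. In an assay on CHO cells for binding affinity to metabotropic glutamate receptor 2 (Rattus norvegicus) (a lower number here means a stronger inhibitor, a higher number a weaker inhibitor), compound 3 gives the highest number of the three: the steps of a 2.5-fold higher number from compound 1 to compound 3 (0.40 log units; beyond the scatter) and a 4.2-fold higher number from compound 2 to compound 3 (0.63 log units; beyond the scatter) are both modest, yet both lie beyond the usual scatter, so compound 3 is the weakest binder among the measured set.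

Compound 4, `N[C@]1(C(=O)O)[C@H]2[C@@H](C[C@H]1OCc1cc(F)ccc1F)[C@]2(F)C(=O)O`, differs from compound 3 only in where the two fluorine atoms sit on that ring: 2,5-difluorophenyl in place of 3,5-difluorophenyl on a saturated chain carbon bound to an oxygen on a saturated carbon. Within the data shown here, no measured step compares two difluorophenyl patterns directly. The steps that come closest are those arriving at the 3,5-difluorophenyl ring, a 2.5-fold higher number from compound 1 to compound 3 (0.40 log units; beyond the scatter) and a 4.2-fold higher number from compound 2 to compound 3 (0.63 log units; beyond the scatter), and they show that exchanging one aromatic group for another at this place moves the number only modestly in this assay. A change that merely relocates one fluorine is therefore expected to give a small step, if any, and a step downward from compound 3 is the more likely direction, roughly a 1.8-fold lower number from compound 3 to compound 4 (0.25 log units; within the scatter). The expected value for compound 4 is 7 nM, with a likely range from 3 nM to 18 nM.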

Compound 4, inhibition constant: 14.4 nM
Compound 4: middle estimate off by 2.1-fold (0.31 log units), on the low side; the measured number falls inside the stated range.
By their numbers in this assay, from the lowest: compounds 2 and 1 (each within the scatter of the next); then compounds 3 and 4 (each within the scatter of the next).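

In this assay, moving one fluorine to give 2,5-difluorophenyl in place of 3,5-difluorophenyl produces a 1.2-fold higher number from compound 3 to compound 4 (0.06 log units; within the scatter), so on a saturated chain carbon bound to an oxygen on a saturated carbon these two fluorine patterns cannot be told apart. The new compound also shows that the gap to the other rings does not depend on this one fluorine pattern: a 4.9-fold higher number from compound 2 to compound 4 (0.69 log units; beyond the scatter) and a 2.9-fold higher number from compound 1 to compound 4 (0.46 log units; beyond the scatter) are both beyond the scatter and run the same way as the steps to compound 3, so among these four compounds the choice between a difluorophenyl ring and the 3-cyanophenyl or 2-chlorophenyl ring matters more than where the fluorines sit. Nothing measured here explains why the two patterns match or why the difluorophenyl compounds give higher numbers.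

Compounds 1 and 2 each carry one group on the ring and compounds 3 and 4 carry two, so the shown set cannot separate the effect of fluorine itself from that of having two ring groups; a ring with a single fluorine, such as 3-fluorophenyl, would address this. Also open, from the compounds shown here alone, is whether a different kind of ring group, such as an amine or a carboxylic acid, would keep the number close to those of compounds 1 and 2.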